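The source may report more compounds than this note shows. Statements on the series, on what has been measured and on what is new or still open speak of the compounds shown alone.

Measured so far in a functional assay on LoVo cells (Homo sapiens) for cytotoxicity, read by MTT assay (a higher number here means a weaker inhibitor, a lower number a stronger inhibitor), are two compounds:
- compound 1 `Oc1ccc(CN(Cc2ccccc2C(F)(F)F)Cc2ccc(O)c3ncccc23)c2cccnc12` gives 93 nM
- compound 2 `Oc1ccc(CN(Cc2cccc(I)c2)Cc2ccc(O)c3ncccc23)c2cccnc12` gives 393 nM

Among the measured compounds shown here, compound 2 holds the higher of the two numbers, and compound 1 is its only neighbour. The next compound, compound 3 `Oc1ccc(CN(Cc2cccs2)Cc2ccc(O)c3ncccc23)c2cccnc12`, differs from compound 2 in one place: thiophen-2-yl in place of 3-iodophenyl on a saturated chain carbon bound to an amine nitrogen.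

For the measured compounds named here, one measured step bears on this change, at the same place: a 4.2-fold higher number from compound 1 to compound 2 (0.63 log units; beyond the scatter) is modest and beyond the scatter. Neither of its groups is thiophen-2-yl, so it offers a rough size and no firm direction. A step no larger than that one is expected in this assay and may not clear the scatter. It should lean slightly toward a lower number, since compound 2 at 393 nM is the higher of the two values. The step expected is a 1.6-fold lower number from compound 2 to compound 3 (0.20 log units; within the scatter) on this estimate. For compound 3 the estimated value is 250 nM with an expected range from 80 nM to 800 nM on present data.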

Compound 3, half-maximal inhibitory concentration: 40 nM
For compound 3 the middle estimate is 6.3-fold (0.80 log units) above the measured one; measured number below the stated range.
By their numbers in this assay, from the lowest: compound 3; then compound 1; then compound 2.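

In this assay, the place on a saturated chain carbon bound to an amine nitrogen proves open to more than substituted phenyl rings: thiophen-2-yl gives a 9.8-fold lower number from compound 2 to compound 3 (0.99 log units; beyond the scatter) and also a 2.3-fold lower number from compound 1 to compound 3 (0.37 log units; beyond the scatter). Compound 3 therefore has the lowest number of the three, with both of its steps beyond the scatter, so the best of the two phenyl groups is not the limit at this place, and a five-membered aromatic ring with one hetero atom, at 5 heavy atoms against 7 for 3-iodophenyl, is tolerated here and does better than either. No measurement in hand accounts for this difference between the groups.

The three compounds do not separate the contribution of ring size, of the ring sulfur and of the absence of any ring substituent, and a plain phenyl, furan-2-yl or thiophen-3-yl at this place would bear on that. Also open, going by these compounds, is whether a non-aromatic group at this place, such as a cyclohexyl ring or a longer alkyl chain, keeps a number in this range in this assay.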